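A few compounds are considered here, and "the series" means these few. Any claim that something is new, unique, unknown or untested is made for them only; others in the source may bear on it.

Going by the values given here, the three compounds measured so far share one core and differ only in the aromatic group sitting on a carbon with a double bond to nitrogen. In a functional assay on HT-29 cells (Homo sapiens) for cytotoxicity, read by MTT assay, with a stated time of 72 h (on this read-out lower numbers stand for stronger inhibition and higher numbers for weaker inhibition), compound 1 `CN(C)CCn1cnnc1-c1cc(Oc2ccc(NC(=O)N/N=C/c3cc(C(C)(C)C)cc(C(C)(C)C)c3O)cc2F)ccn1` gives 680 nM. Compound 2 `COc1ccc(OC)c(/C=N/NC(=O)Nc2ccc(Oc3ccnc(-c4nncn4CCN(C)C)c3)c(F)c2)c1` gives 2070 nM, the highest of the three numbers. Its nearest neighbour is compound 3 `CN(C)CCn1cnnc1-c1cc(Oc2ccc(NC(=O)N/N=C/c3ccc(F)cc3)cc2F)ccn1`, which gives 1370 nM, and the step of a 1.5-fold lower number from compound 2 to compound 3 (0.18 log units; within the scatter) stays within the scatter, whereas compound 1 stands furthest from compound 2, beyond the scatter.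

Compound 4 `CN(C)CCn1cnnc1-c1cc(Oc2ccc(NC(=O)N/N=C/c3ccc(F)cc3F)cc2F)ccn1` differs from compound 2 by 2,4-difluorophenyl in place of 2,5-dimethoxyphenyl on a carbon with a double bond to nitrogen. Among the compounds with values here, the only measured step that bears on this change is a 1.5-fold lower number from compound 2 to compound 3 (0.18 log units; within the scatter), in which a single fluorine on the same aromatic ring replaced the two methoxy groups and produced no shift beyond the scatter. Within the data shown here, no measured pair shows what a second fluorine adds on top of that, so the expectation rests on compound 3 alone. Compound 4 is therefore expected to behave like compound 3, and the expected step of a 1.6-fold lower number from compound 2 to compound 4 (0.20 log units; within the scatter) is estimated to remain within the scatter. Compound 4 is estimated at 1300 nM, with a range from 600 nM to 2800 nM.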

Compound 4, half-maximal inhibitory concentration: 960 nM
Estimate against measurement, compound 4: 1.4-fold (0.13 log units) above; low and high end bracket the measured number.
By their numbers in this assay, from the lowest: compounds 1, 4, 3 and 2 (each within the scatter of the next, the first and the last beyond it).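

In this assay, going by these compounds alone, the replacement of 2,5-dimethoxyphenyl on a carbon with a double bond to nitrogen now gives a fluorinated ring a step that passes the scatter, a 2.2-fold lower number from compound 2 to compound 4 (0.33 log units; beyond the scatter), which the single fluorine of compound 3 did not give. The added fluorine by itself cannot be credited with that change: fluoro in place of hydrogen on an aromatic carbon gives a 1.4-fold lower number from compound 3 to compound 4 (0.15 log units; within the scatter), so compound 3 and compound 4 cannot be told apart in this read-out, and the step from compound 2 only narrowly clears the scatter. Nothing available here gives a measured reason for either step, and the numbers alone must stand without an explanation.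

The compounds shown leave open whether fluorine matters at all beyond removing the two methoxy groups, since no unsubstituted phenyl ring stands among them to anchor the comparison. They also leave open how this position would respond to a quite different group on the same carbon, such as a carboxylic acid or an amine on the aromatic ring, or a cyclohexyl ring in place of the aromatic ring.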